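Indole and indazole biaryls: expectation for the dimethylpyridine analogue

A few compounds are considered here, and "the series" means these few. Any claim that something is new, unique, unknown or untested is made for them only; others in the source may bear on it.

Measured compounds:
compound 1 `COc1cc2cc[nH]c2cc1-c1ccncc1`: 2 nM
compound 2 `COc1cc2cn[nH]c2cc1-c1ccncc1`: 51 nM
compound 3 `COc1cc2c(C(=O)N3CCN(C)CC3)n[nH]c2cc1-c1ccncc1`: 39 nM

In an assay for antagonist activity at Toll-like receptor 8 (Homo sapiens), read by TR-FRET (a higher number here means a weaker inhibitor, a lower number a stronger inhibitor), compound 3 gives 39 nM, the second highest of the three numbers. Its nearest neighbour is compound 2, whose value in this assay lies within the scatter of it; the furthest is compound 1, which stands beyond the scatter with the lowest number of the set.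

Compound 4 `COc1cc2c(C(=O)N3CCN(C)CC3)n[nH]c2cc1-c1cc(C)nc(C)c1` has not been measured. It differs from compound 3 by 2,6-dimethylpyridin-4-yl in place of pyridin-4-yl on an aromatic carbon. Within the data shown here, no pair among the measured compounds isolates this change, so no step can be drawn from them. The expectation is a step from compound 3 to compound 4 of a 1.3-fold lower number from compound 3 to compound 4 (0.11 log units; within the scatter), not clearly beyond the scatter in either direction. Compound 4 is therefore estimated at 30 nM, with a range from 8 nM to 110 nM.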

Compound 4, half-maximal inhibitory concentration in the Toll-like receptor 8 assay: 23 nM
Compound 4: middle estimate off by 1.3-fold (0.12 log units), on the high side, within the range that was stated.
By their numbers in the Toll-like receptor 8 assay, from the lowest: compound 1; then compounds 4, 3 and 2 (each within the scatter of the next, the first and the last beyond it).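

At this position, on an aromatic carbon ortho to a methoxy group, 2,6-dimethylpyridin-4-yl can replace pyridin-4-yl with no clear loss: in the Toll-like receptor 8 assay the change gives a 1.7-fold lower number from compound 3 to compound 4 (0.23 log units; within the scatter). In a physicochemical assay for acid dissociation, compound 3 gives 5.3 and compound 4 gives 6.7. The same change moves the physicochemical assay beyond the scatter: the measured acid dissociation constant of compound 3, 5.3, and of compound 4, 6.7, a number 1.40 log units higher (beyond the scatter) In this single pair, that large shift comes without a step beyond the scatter in the Toll-like receptor 8 assay.

Open, going by these compounds, is whether a pyridin-4-yl bearing a single methyl, or an amine in place of the methyl groups, would read the same in the Toll-like receptor 8 assay. Also open, on these data alone, is whether the change carries over to the core of compound 1.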